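A few compounds are considered here, and "the series" means these few. Any claim that something is new, unique, unknown or untested is made for them only; others in the source may bear on it.

Working notes on the series.

The three measured compounds share one core and differ only in the dialkylamino group. Compound 1 `Cc1ccc(NC(=O)Nc2cc(-c3ccccc3C(=O)O)ccc2N(C)C2CCCCC2)cc1` gives 14 nM in an assay on HeLa cells for inhibition of Indoleamine 2,3-dioxygenase 1 (Homo sapiens), with stated times of 1 h and 18 h; a lower number here means a stronger inhibitor, a higher number a weaker inhibitor. Compound 2 `CCCCN(CCCC)c1ccc(-c2ccccc2C(=O)O)cc1NC(=O)Nc1ccc(C)cc1` gives 45 nM in this assay. Compound 3 `Cc1ccc(NC(=O)Nc2cc(-c3ccccc3C(=O)O)ccc2N(CC(C)C)CC(C)C)cc1` gives 13 nM in this assay, the lowest of the three numbers, though its gap to compound 1 lies within the scatter; only compound 2 sits apart from it.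

The measured steps: a 3.2-fold higher number from compound 1 to compound 2 (0.51 log units; beyond the scatter), a 1.1-fold lower number from compound 1 to compound 3 (0.03 log units; within the scatter), and a 3.5-fold lower number from compound 2 to compound 3 (0.54 log units; beyond the scatter). The two branched groups, cyclohexyl(methyl)amino and diisobutylamino, therefore sit together, while the straight dibutylamino gives the weaker number.

Compound 4 `Cc1ccc(NC(=O)Nc2cc(-c3ccccc3C(=O)O)ccc2N(CC2CC2)CC2CC2)cc1` is not yet measured. It differs from compound 3 as follows: bis(cyclopropylmethyl)amino in place of diisobutylamino on an aromatic carbon. The group that enters keeps the same count of heavy atoms and of donors and acceptors as the one that leaves; the branching is replaced by two three-membered rings. For the measured compounds named here, the steps that bear on this are those between compound 1, compound 2 and compound 3 above: the two branched groups gave nothing beyond the scatter between them, and only the straight chain moved the number. Going by the values given here, no measured step covers a ring of this kind, so the expectation rests on the closeness of compound 1 and compound 3.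

The expectation for compound 4 is a number close to that of compound 3, with the step of a 1.4-fold higher number from compound 3 to compound 4 (0.14 log units; within the scatter) not expected to go beyond the scatter. The estimate for compound 4 in this assay is 18 nM, with a range from 8 nM to 45 nM.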

Compound 4, half-maximal inhibitory concentration: 348 nM
Compound 4: middle estimate off by 19-fold (1.29 log units), on the low side; measured number above the stated range.
By their numbers in this assay, from the lowest: compounds 3 and 1 (each within the scatter of the next); then compound 2; then compound 4.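

At the position on an aromatic carbon para to a 2-carboxyphenyl group, the change to bis(cyclopropylmethyl)amino in this assay gives a large step (a 27-fold higher number from compound 3 to compound 4 (1.43 log units; beyond the scatter)) even though heavy atoms, donors and acceptors keep the same counts, so these counts do not track the number here. For the compounds shown here, the same group also stands apart from the other two amino groups (a 7.7-fold higher number from compound 2 to compound 4 (0.89 log units; beyond the scatter); a 25-fold higher number from compound 1 to compound 4 (1.40 log units; beyond the scatter)), which shows a much wider spread at this position than the earlier compounds did, and compound 4 goes against the earlier reading that only the straight chain moves the number. No measured evidence in hand accounts for this step.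

The compounds shown leave open whether one three-membered ring is enough for the step, which an amine carrying one cyclopropylmethyl and one isobutyl group would address, and whether ring size matters, which bis(cyclobutylmethyl)amino would address. They also leave open whether the step keeps its size when a 4-chlorophenyl group takes the place of the 4-methylphenyl group in the ((4-methylphenyl)carbamoyl)amino group.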